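Amide aryl swap and kinetic solubility in the series

The compounds below may be only part of what the source reports. "The series", "measured", "known", "first", "only" and "open" are said of these compounds alone.

Compound 3 `CC(C)(C)c1cc(C(=O)Nc2nc(CO)cs2)n(Cc2ccccc2)n1` gives 3.1 ug/mL in a physicochemical assay for solubility, read by nephelometry, measured as kinetic solubility, at pH 6.5 (a higher number here means a more soluble compound, a lower number a less soluble compound), the lowest of the two numbers in hand. Compound 2 `CC(C)(C)c1cc(C(=O)Nc2cccnc2)n(Cc2ccccc2)n1` gives 6.3 ug/mL in this assay. Compound 1 `Cc1csc(NC(=O)c2cc(C(C)(C)C)nn2Cc2ccccc2)n1` gives only a limit in this assay, < 1.6 ug/mL. The step to compound 4 `CC(C)(C)c1cc(C(=O)Nc2cccc(CN)c2)n(Cc2ccccc2)n1` is 3-(aminomethyl)phenyl in place of 4-(hydroxymethyl)-1,3-thiazol-2-yl on an amide-type nitrogen. Two measured steps change the same amide-type nitrogen substituent: an at least 3.9-fold higher number from compound 1 to compound 2 (0.59 log units; beyond the scatter) and a 2.0-fold lower number from compound 2 to compound 3 (0.31 log units; beyond the scatter); a third, an at least 1.9-fold higher number from compound 1 to compound 3 (0.28 log units; that floor lies within the scatter), stays within the scatter and rests on (the limit of < 1.6 ug/mL in this assay, at which 1 of the 3 values shown sits). Exchanging the five-membered aromatic ring with 2 hetero atoms for a six-membered aromatic ring of carbon only went with a higher number in this assay once, from compound 1 to compound 2, so a rise of at least that order is expected for compound 4, the direction firmer than the size, as a 6.5-fold higher number from compound 3 to compound 4 (0.81 log units; beyond the scatter). Compound 4 is accordingly estimated at 20 ug/mL, within 5 ug/mL to 80 ug/mL.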

Compound 4, solubility: 25 ug/mL
Compound 4: the middle estimate sits 1.3-fold (0.10 log units) below what was measured; the range from low to high includes it.
By their numbers in this assay, from the lowest: compound 3; then compound 2; then compound 4. At a limit, below all of these: compound 1.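

For the compounds shown here, at this amide-type nitrogen, 3-(aminomethyl)phenyl gives the highest number so far in this assay, with an 8.1-fold higher number from compound 3 to compound 4 (0.91 log units; beyond the scatter) and a 4.0-fold higher number from compound 2 to compound 4 (0.60 log units; beyond the scatter), so a substituent now stands clearly above both 4-(hydroxymethyl)-1,3-thiazol-2-yl and pyridin-3-yl. The earlier compounds shown here left the top of the range at pyridin-3-yl, and the ceiling at this position now lies higher. The step from 4-methyl-1,3-thiazol-2-yl, an at least 15-fold higher number from compound 1 to compound 4 (1.19 log units; beyond the scatter), is only a floor, as compound 1 gives a limit: the limit of < 1.6 ug/mL in this assay, at which 1 of the 4 values shown sits.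

The change replaces the ring and adds the aminomethyl group at once, so the compounds shown do not separate the share of each. A plain phenyl, 3-(hydroxymethyl)phenyl or a carboxylic acid on the same ring would divide the step between ring and side chain.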